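This account rests on a few compounds, and the source may have more. Where it says the series, first, only, none or still open, it means among the compounds named here.

Working notes on the series. Compound 1 `CCS(=O)(=O)Nc1cc(-c2ccc3ncnc(Nc4ccc(OC(F)(F)F)cc4)c3c2)cnc1OC`, compound 2 `CCS(=O)(=O)Nc1cc(-c2ccc3ncnc(Nc4ccc(OC)c(OC)c4)c3c2)cnc1OC` and compound 3 `CCS(=O)(=O)Nc1cc(-c2ccc3ncnc(Nc4ccc(OCc5ccc(F)cc5)c(Cl)c4)c3c2)cnc1OC` share one core and differ only in the group on a nitrogen on an aromatic ring. In a functional assay on A549 cells (Homo sapiens) for cytotoxicity, read by sulforhodamine B assay, with a stated time of 72 h (on this read-out lower numbers stand for stronger inhibition and higher numbers for weaker inhibition), compound 2 gives 5820 nM, the lowest number of the three; compound 1 gives 25400 nM and compound 3 gives 31300 nM. Among the measured compounds shown here, the single step between compounds differing in one place, a 4.4-fold lower number from compound 1 to compound 2 (0.64 log units; beyond the scatter), shows that the group at this position shifts the number beyond the scatter. Compound 4 `CCS(=O)(=O)Nc1cc(-c2ccc3ncnc(Nc4ccc(F)nc4)c3c2)cnc1OC` carries 6-fluoropyridin-3-yl in place of 3,4-dimethoxyphenyl on a nitrogen on an aromatic ring. For the measured compounds named here, no measured step matches this change; the values of compound 2 and compound 1 only show that 3,4-dimethoxyphenyl gives the lowest number so far. The expectation is a 2.6-fold higher number from compound 2 to compound 4 (0.41 log units; beyond the scatter). Compound 4 is estimated at 15000 nM, range 5000 nM to 50000 nM.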

Compound 4, half-maximal inhibitory concentration: 6720 nM
Beside the measured number, compound 4's estimate is 2.2-fold (0.35 log units) above it; measured number inside the range.
By their numbers in this assay, from the lowest: compounds 2 and 4 (each within the scatter of the next); then compounds 1 and 3 (each within the scatter of the next).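

A step of a 1.2-fold higher number from compound 2 to compound 4 (0.06 log units; within the scatter) in this assay places 6-fluoropyridin-3-yl level with 3,4-dimethoxyphenyl on this nitrogen, so neither the methoxy groups nor a ring of carbon only is required for the lowest numbers seen so far. The same group still stands apart from 4-(trifluoromethoxy)phenyl, with a 3.8-fold lower number from compound 1 to compound 4 (0.58 log units; beyond the scatter) as the step. Nothing measured here explains why these groups fall as they do.

Still open, as far as these compounds go, is whether the fluorine or the ring nitrogen of 6-fluoropyridin-3-yl matters more, and where an unsubstituted pyridin-3-yl or a pyridin-3-yl bearing an amine would fall.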